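Substituent change on the outer phenyl in a cytotoxicity series

This account rests on a few compounds, and the source may have more. Where it says the series, first, only, none or still open, it means among the compounds named here.

Three compounds of the shared core have numbers in a functional assay on Caco-2 cells (Homo sapiens) for cytotoxicity, with a stated time of 48 h; a higher number here means a weaker inhibitor, a lower number a stronger inhibitor. Compound 1 `O=[N+]([O-])c1ccc(CN2CCC(n3cc(CC(OCc4cc(-c5ccccc5)no4)c4ccc(Br)cc4)nn3)CC2)cc1` gives 7000 nM. Compound 2 `O=[N+]([O-])c1ccc(CN2CCC(n3cc(CC(OCc4cc(-c5ccc(Br)cc5)no4)c4ccc(Br)cc4)nn3)CC2)cc1` gives 3000 nM, and compound 3 `COc1ccc(-c2cc(COC(Cc3cn(C4CCN(Cc5ccc([N+](=O)[O-])cc5)CC4)nn3)c3ccc(Br)cc3)on2)cc1` gives 3000 nM. Compound 3 stands level with compound 2 at the digits shown, the two together the lowest of the three; the step of no change at the digits printed from compound 2 to compound 3 (within the scatter) lies within the scatter, whereas a 2.3-fold lower number from compound 1 to compound 3 (0.37 log units; beyond the scatter) and a 2.3-fold lower number from compound 1 to compound 2 (0.37 log units; beyond the scatter) are beyond it.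

Compound 4 `O=[N+]([O-])c1ccc(CN2CCC(n3cc(CC(OCc4cc(-c5cccc(F)c5)no4)c4ccc(Br)cc4)nn3)CC2)cc1` differs from compound 3 in one place: 3-fluorophenyl in place of 4-methoxyphenyl on an aromatic carbon. For the measured compounds named here, the steps that bear on this are a 2.3-fold lower number from compound 1 to compound 3 (0.37 log units; beyond the scatter), which the loss of the methoxy would reverse, and no change at the digits printed from compound 2 to compound 3 (within the scatter), which gives the same number for methoxy and bromo. Going by the values given here, no measured step covers a fluorine. The step of a 1.7-fold higher number from compound 3 to compound 4 (0.22 log units; within the scatter) is therefore expected to be small, toward a higher number and at most of the size seen on going from compound 1 to compound 3. Compound 4 is expected to give 5000 nM, with a range from 2500 nM to 10000 nM.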

Compound 4, half-maximal inhibitory concentration: 5000 nM
Compound 4: middle estimate and measured number agree at the digits printed; low and high end bracket the measured number.
By their numbers in this assay, from the lowest: compounds 2, 3, 4 and 1 (each within the scatter of the next, the first and the last beyond it).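

In this assay the 3-fluorophenyl group of compound 4 cannot be told apart from any of the three earlier groups on this carbon of the five-membered ring (a 1.7-fold higher number from compound 3 to compound 4 (0.22 log units; within the scatter)) (a 1.7-fold higher number from compound 2 to compound 4 (0.22 log units; within the scatter)) (a 1.4-fold lower number from compound 1 to compound 4 (0.15 log units; within the scatter)). The earlier compounds shown here showed only a separation of the unsubstituted phenyl from 4-bromophenyl and 4-methoxyphenyl, and compound 4 now bridges that separation, leaving a continuous run of values with only its two ends beyond the scatter. No measurement on these compounds accounts for these small differences.

The step to 3-fluorophenyl changes both the substituent and where it sits on the phenyl, so the two contributions remain unseparated. On these data alone, whether an amine or a carboxylic acid on this phenyl would move the number outside this narrow span remains open.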